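Compound 3 and the Replacement of 4-Butoxyphenyl

This account rests on a few compounds, and the source may have more. Where it says the series, first, only, none or still open, it means among the compounds named here.

Values from a functional assay on MDA-MB-231 cells (Homo sapiens) for antiproliferative activity, read by MTT assay, with a stated time of 24 h (on this read-out lower numbers stand for stronger inhibition and higher numbers for weaker inhibition), for two compounds
Compound 1 (`Cc1cccc(NNC(=O)c2ccc(NS(=O)(=O)c3cnc(O)nc3O)cc2)c1`) gives > 20000 nM as a limit of the assay
Compound 2 (`CCCCOc1ccc(C(=O)NNC(=O)c2cccc(NS(=O)(=O)c3cnc(O)nc3O)c2)cc1`) gives 17000 nM as a number

Among the measured compounds shown here, compound 2 holds the only true number in this assay (17000 nM). The one other result, that of compound 1, is a limit and cannot be placed on the same scale as a number.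

Compound 3 (`O=C(NNC(=O)c1ccccc1F)c1cccc(NS(=O)(=O)c2cnc(O)nc2O)c1`) keeps the shared core of compound 2 and changes a single group on a carbonyl carbon, with 2-fluorophenyl in place of 4-butoxyphenyl (2-fluorophenyl in place of 4-butoxyphenyl on a carbonyl carbon). For the measured compounds named here, no step between measured compounds is available as a guide, so the expectation rests on compound 2 alone (17000 nM). In this assay no change beyond the scatter is expected, and a result reported only as a limit would not be a surprise. The estimated step runs a 1.2-fold higher number from compound 2 to compound 3 (0.07 log units; within the scatter) and has no firm direction. For compound 3 the expected value is 20000 nM with an estimated range (9000 nM to 45000 nM).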

Compound 3, half-maximal inhibitory concentration: > 20000 nM
Compound 3 ended at the assay's limit; the forecaster's own chance of this, stated with the estimate: 50%; the middle value lies on the limit itself.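

Among the compounds shown here, the step of an at least 1.1-fold higher number from compound 2 to compound 3 (0.07 log units; that floor lies within the scatter) is the first one between measured compounds in this assay and replaces 4-butoxyphenyl with 2-fluorophenyl on a carbonyl carbon whose other neighbour is an amide-type nitrogen. Compound 3 gives > 20000 nM as a limit of the assay and not as a number, so the step is only a floor, and that floor lies within the scatter. For the compounds shown here, what this adds is that the change at this position does not produce a second true number, so the only one remains that of compound 2, while the result of compound 3 joins the other limit: the limit of > 20000 nM in this assay, at which 2 of the 3 values shown sit.

On these data alone, how far the true value of compound 3 lies from that limit stays unknown, and the result cannot tell whether 4-butoxyphenyl makes any real difference to the number of compound 2. The compounds shown also leave open how an amine, a carboxylic acid or a longer chain on the same carbonyl carbon would read in this assay.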